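The compounds below may be only part of what the source reports. "The series", "measured", "known", "first", "only" and "open" are said of these compounds alone.

Measured in an ADME assay on MT4 cells (Homo sapiens) for cytotoxicity, with a stated time of 5 days; a lower number here means that less compound is tolerated, a higher number that more compound is tolerated:
- Compound 1 `CC1CC=C(C(=O)N(c2cc(C#CC(C)(C)C)sc2C(=O)O)C(C)C)CC1`: > 20000 nM, a limit
- Compound 2 `CC(C)N(c1cc(C#CC(C)(C)C)sc1C(=O)O)C(=O)[C@H]1CC[C@H](C)CC1`: > 20000 nM, a limit
- Compound 3 `CC(C)N(C(=O)[C@H]1[C@@H]2CCCC[C@@H]21)c1cc(C#CC(C)(C)C)sc1C(=O)O`: > 20000 nM, a limit

Compound 3 stands at > 20000 nM, which is a limit and not a number. The three measured compounds share (the limit of > 20000 nM in this assay, at which 3 of the 3 values shown sit). Compound 4 `CC(C)N(C(=O)[C@H]1CC[C@@H]2C[C@@H]2CC1)c1cc(C#CC(C)(C)C)sc1C(=O)O` differs from compound 3 on a carbonyl carbon: a group of 8 heavy atoms (8 carbon; one three-membered non-aromatic ring of carbon only, one seven-membered non-aromatic ring of carbon only) in place of a group of 7 heavy atoms (7 carbon; one three-membered non-aromatic ring of carbon only, one six-membered non-aromatic ring of carbon only), on a carbonyl carbon. The nearest measured changes on that carbonyl carbon are a step that the two limits leave unreadable from compound 1 to compound 3 and a step that the two limits leave unreadable from compound 2 to compound 3, and a step that the two limits leave unreadable from compound 1 to compound 2 adds no readable size. Resting on compound 3 at > 20000 nM, no step beyond the scatter is expected in this assay. The expected size is a step that the limit leaves unreadable from compound 3 to compound 4. For compound 4 the estimate is 22000 nM, with an expected range of 10000 nM to 50000 nM.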

Compound 4, half-maximal cytotoxic concentration: > 20000 nM
Compound 4 was reported as a limit; the forecaster's own chance of this, stated with the estimate: 85%; the middle value is on the limit's open side.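

Going by these compounds alone, compound 4 gives > 20000 nM, a limit, so no step to it from compound 1, compound 2 or compound 3 can be read in this assay. The compounds shown leave open how far any of them lies past the shared limit: the limit of > 20000 nM in this assay, at which 4 of the 4 values shown sit.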